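Moving the Nitro Group on the Sulfonyl Aryl Ring

The source may hold more compounds than are shown below. What is called first, only, known or untested is meant among the compounds shown, and "the series" means these compounds.

Of the compounds shown here, three built on one shared core have been tested in a functional assay on PC-3 cells (Homo sapiens) for inhibition; a lower number here means a stronger inhibitor, a higher number a weaker inhibitor. Compound 1 `COc1cc2nc(N3CCN(S(=O)(=O)c4ccc(Cl)cc4)CC3)nc(N)c2cc1OC` gives 23000 nM. Compound 2 `COc1cc2nc(N3CCN(S(=O)(=O)c4ccc(Br)cc4)CC3)nc(N)c2cc1OC` gives 20000 nM, and the change a 1.2-fold lower number from compound 1 to compound 2 (0.06 log units; within the scatter) is too small to read as a real difference. Compound 3 `COc1cc2nc(N3CCN(S(=O)(=O)c4ccccc4[N+](=O)[O-])CC3)nc(N)c2cc1OC` gives 35000 nM. For the measured compounds named here, on the numbers, compound 3 carries the highest value of the three, yet both steps leading to it, a 1.5-fold higher number from compound 1 to compound 3 (0.18 log units; within the scatter) and a 1.8-fold higher number from compound 2 to compound 3 (0.24 log units; within the scatter), sit within the scatter, so no compound can be called weaker or stronger than another.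

Compound 4 `COc1cc2nc(N3CCN(S(=O)(=O)c4cccc([N+](=O)[O-])c4)CC3)nc(N)c2cc1OC` has not yet been measured. It differs from compound 3 in a single place: 3-nitrophenyl in place of 2-nitrophenyl on a sulfonyl sulfur. Going by the values given here, the only measured steps that touch the same place are the two swaps of the aryl group on the sulfonyl sulfur already named, and neither moved the number beyond the scatter. Among the compounds with values here, no measured pair compares two nitrophenyl groups with each other, so the data say nothing direct about where the nitro group sits.

The step expected in this assay is therefore a 1.2-fold lower number from compound 3 to compound 4 (0.07 log units; within the scatter), meaning no change beyond the scatter. For compound 4 the estimated value is 30000 nM, with a likely range from 12000 nM to 75000 nM.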

Compound 4, half-maximal inhibitory concentration: 32000 nM
Estimate against measurement, compound 4: 1.1-fold (0.03 log units) below; low and high end bracket the measured number.
By their numbers in this assay, from the lowest: compounds 2, 1, 4 and 3 (each within the scatter of the next).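

For the compounds shown here, this is the first pair that compares two nitrophenyl groups directly. In this assay, putting 3-nitrophenyl in place of 2-nitrophenyl on the sulfonyl sulfur gives no readable difference (the step is a 1.1-fold lower number from compound 3 to compound 4 (0.04 log units; within the scatter)), so the data do not separate these two placements of the nitro group. Compound 4 also cannot be told apart from the two halogen-bearing compounds (the steps are a 1.6-fold higher number from compound 2 to compound 4 (0.20 log units; within the scatter) and a 1.4-fold higher number from compound 1 to compound 4 (0.14 log units; within the scatter)), so 4-chlorophenyl, 4-bromophenyl, 2-nitrophenyl and 3-nitrophenyl all read alike at this place in this assay, and nothing available explains why these swaps leave the number where it is.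

The compounds shown leave open whether any change of the aryl group on this sulfur can move the number beyond the scatter at all. A 4-nitrophenyl group would complete the set of nitro placements, and an aryl ring carrying an amine or a carboxylic acid would test a very different kind of group at the same place.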